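Swapping Methoxy for Fluoro on a Different Core

The source may hold more compounds than are shown below. What is called first, only, known or untested is meant among the compounds shown, and "the series" means these compounds.

Compound 1, `COc1cc(C=C(C(=O)/C=C/c2cccc(OC)c2OC)C(=O)/C=C/c2cccc(OC)c2OC)ccc1O`, carries a 4-hydroxy-3-methoxyphenyl group. In a functional assay on MCF7 cells (Homo sapiens) for antiproliferative activity, read by sulforhodamine B assay, with a stated time of 48 h (a higher number here means a weaker inhibitor, a lower number a stronger inhibitor), compound 1 gives 480 nM. Compound 2, `COc1cccc(/C=C/C(=O)C(=Cc2ccc(O)c(F)c2)C(=O)/C=C/c2cccc(OC)c2OC)c1OC`, differs from it in one place: fluoro in place of methoxy on an aromatic carbon. In this assay compound 2 gives 300 nM, and the step is a 1.6-fold lower number from compound 1 to compound 2 (0.20 log units; within the scatter).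

Compound 3, `COc1cc(OC)c(/C=C/C(=O)C(=Cc2ccc(O)c(OC)c2)C(=O)/C=C/c2c(OC)cc(OC)cc2OC)c(OC)c1`, keeps the 4-hydroxy-3-methoxyphenyl group but sits on another core; how its core differs from the core of compound 1 is not broken down here. In this assay compound 3 gives 1880 nM, the highest of the three numbers, and its distance from both compound 1 and compound 2 lies beyond the scatter.

Compound 4, `COc1cc(OC)c(/C=C/C(=O)C(=Cc2ccc(O)c(F)c2)C(=O)/C=C/c2c(OC)cc(OC)cc2OC)c(OC)c1`, has not yet been measured. It differs from compound 3 in one place: fluoro in place of methoxy on an aromatic carbon. This is the same change as from compound 1 to compound 2, made at the same place on the same kind of ring. For the measured compounds named here, because the earlier step was a 1.6-fold lower number from compound 1 to compound 2 (0.20 log units; within the scatter), a step of similar size is expected here, with the caution that only one earlier example exists and that a different core may carry the same change differently. Compound 4 is therefore expected to give 1300 nM in this assay, most likely between 500 nM and 3500 nM. The step this estimate means is expected to be a 1.4-fold lower number from compound 3 to compound 4 (0.16 log units; within the scatter).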

Compound 4, half-maximal inhibitory concentration: 3180 nM
Beside the measured number, compound 4's estimate is 2.4-fold (0.39 log units) below it; low and high end bracket the measured number.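

In this assay, the swap from 4-hydroxy-3-methoxyphenyl to 3-fluoro-4-hydroxyphenyl on the second core gives a 1.7-fold higher number from compound 3 to compound 4 (0.23 log units; within the scatter). Set beside the same swap on the core of compound 1, this shows that a change that is identical on paper need not give the same result on both cores, so the step from one core cannot simply be carried over to the other: the same change on two cores in this assay, a 1.6-fold lower number (0.20 log units; within the scatter) from compound 1 to compound 2 and a 1.7-fold higher number (0.23 log units; within the scatter) from compound 3 to compound 4, 2.7-fold (0.43 log units) apart, beyond the scatter of two such steps. For the compounds shown here, each step taken alone stays within the scatter, so neither core shows a real gain or loss from the swap, and with only one pair per core the data cannot show what in the cores separates the two results or whether the gap would appear again in a repeat or with other changes.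

The compounds shown carry only methoxy or fluoro at this place, always with the hydroxy group kept, so it remains open how chloro, an amine or a longer chain such as ethoxy would behave there on either core. On these data alone, it also remains open whether a third core would follow the core of compound 1, the core of compound 3 or neither.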